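Trimming the Alkyl Group on the Azole Nitrogen

The compounds below may be only part of what the source reports. "The series", "measured", "known", "first", "only" and "open" are said of these compounds alone.

Of the compounds shown here, three have been measured in a functional assay with Alpha-1D adrenergic receptor (Homo sapiens) as the target, read by calcium flux; a lower number here means a smaller maximal response, a higher number a larger maximal response. Compound 3 `CCn1cccc1-c1ccccc1NCC1=NCCN1` gives 0%. Compound 1 `Cn1cccc1-c1ccccc1NCC1=NCCN1` gives 32% in this assay. The change between these two, (hydrogen in place of methyl on a saturated chain carbon bound to an aromatic nitrogen), produced the step of a number 32 percentage points higher from compound 3 to compound 1 (beyond the scatter). Compound 2 `CC(C)n1nccc1-c1ccccc1NCC1=NCCN1` gives 0% in this assay, level with compound 3 at the digits shown; the difference between the core of compound 2 and the core of compound 3 is not broken down here.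

Compound 4 `CCn1nccc1-c1ccccc1NCC1=NCCN1` has not yet been measured. It differs from compound 2 by hydrogen in place of methyl on a saturated chain carbon bound to an aromatic nitrogen and a saturated chain carbon. Within the data shown here, this is the same kind of change as the one from compound 3 to compound 1, but not the same: in compound 2 the carbon that loses the methyl is bound to an aromatic nitrogen and a saturated chain carbon, whereas in compound 3 it is bound to an aromatic nitrogen alone.

Among the measured compounds shown here, only one measured pair shows this kind of change, and it sits on a different core, so a more cautious rise is expected. Compound 4 is expected to reach 10% in this assay. The expected range for compound 4 runs from 0% to 35%. For the measured compounds named here, the expected step of a number 10 percentage points higher from compound 2 to compound 4 (within the scatter) is kept smaller than the measured one because the only guide is the step of a number 32 percentage points higher from compound 3 to compound 1 (beyond the scatter), seen on another core.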

Compound 4, largest response reached (reported as maximal response), in percent of the reference or control that the assay uses: 0%
Beside the measured number, compound 4's estimate is 10 percentage points above it, and the stated range covers the measured number.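

In this assay, trimming isopropyl to ethyl on the core of compound 2 gives no change at the digits printed from compound 2 to compound 4 (within the scatter), while the same kind of trim on the other core, from ethyl to methyl, gives a number 32 percentage points higher from compound 3 to compound 1 (beyond the scatter). A gain seen on one core therefore cannot simply be carried over to the other in this series, and the two steps do differ in size: the same change on two cores in this assay, a number 32 percentage points higher (beyond the scatter) from compound 3 to compound 1 and no change at the digits printed (within the scatter) from compound 2 to compound 4, 32 percentage points apart, beyond the scatter of two such steps. What this does not show is the source of the gap, since the two pairs differ both in their core and in the carbon that loses the methyl, so a single comparison cannot separate these two differences, nor can it say how the change would behave on any further core.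

The compounds shown leave open whether a methyl group in this same place on the core of compound 4 would bring a response like that of compound 1, which would test the core directly. They also leave open how a longer chain, or a chain carrying an amine or a carboxylic acid, would fare on the aromatic nitrogen of either core.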